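Methoxy in place of hydroxy on a cinnamoyl benzoxaborole

The source may report more compounds than this note shows. Statements on the series, on what has been measured and on what is new or still open speak of the compounds shown alone.

Measured compounds, with their values in an ADME assay on L929 cells (Mus musculus) for cytotoxicity, read by resazurin assay, with a stated time of 72 h; on this read-out higher numbers stand for weaker inhibition and lower numbers for stronger inhibition:
Compound 1, `O=C(/C=C/c1ccc2c(c1)B(O)OC2)c1ccc(O)cc1`, is reported at the limit > 10 ug/mL.
Compound 2, `O=C(/C=C/c1ccc2c(c1)B(O)OC2)c1ccc(O)c(O)c1`, is reported at the limit > 10 ug/mL.
Compound 3, `COc1cc(C(=O)/C=C/c2ccc3c(c2)B(O)OC3)cc(OC)c1OC`, is reported at the limit > 10 ug/mL.

Compound 1 stands only at a limit in this assay, not at a number, and the same holds for the two other measured compounds, as the summary the limit of > 10 ug/mL in this assay, at which 3 of the 3 values shown sit, records. Among the compounds with values here, the single measured step, a step that the two limits leave unreadable from compound 1 to compound 2, is therefore unreadable: a hydroxy in place of hydrogen on an aromatic carbon may have shifted the value in either direction without leaving the limit.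

Compound 4, `COc1ccc(C(=O)/C=C/c2ccc3c(c2)B(O)OC3)cc1`, is not yet measured. It differs from compound 1 by methyl in place of hydrogen on an oxygen on an aromatic ring. The measured step from compound 1 to compound 2 bears on it only as a sign that a change of similar scope on the same ring stayed within the limit; its size is not known. No step beyond the scatter can be read from the data, so none is expected here, and an outcome at the limit again seems the most likely. Compound 4 is expected at 15 ug/mL in this assay, within the range 8 ug/mL to 40 ug/mL, which corresponds to an expected step that the limit leaves unreadable from compound 1 to compound 4.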

Compound 4, half-maximal inhibitory concentration: > 10 ug/mL
Compound 4 ended at the assay's limit; the forecaster's own chance of this, stated with the estimate: 85%; the middle value does not contradict the limit.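

Within the data shown here, compound 1 and compound 4 both stand only at a limit in this assay, so no step from one to the other can be read, and the change from hydroxy to methoxy has no readable size: the limit of > 10 ug/mL in this assay, at which 4 of the 4 values shown sit. The compounds shown leave open where any of the four would fall as an actual number in this assay, and whether any change among them moves it.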